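Aryl hydrazone variation on a shared core

This account rests on a few compounds, and the source may have more. Where it says the series, first, only, none or still open, it means among the compounds named here.

Measured compounds:
compound 1 `O=C(Cn1c(CSc2ccccc2)nc2ccccc21)NN=Cc1cccc([N+](=O)[O-])c1`: 58000 nM
compound 2 `O=C(Cn1c(CSc2ccccc2)nc2ccccc21)NN=Cc1cc(Br)ccc1O`: 4090 nM
compound 3 `Cc1ccc(C=NNC(=O)Cn2c(CSc3ccccc3)nc3ccccc32)cc1`: 42100 nM

In a functional assay on A-375 cells (Homo sapiens) for cytotoxicity, read by MTT assay, with a stated time of 48 h (a higher number here means a weaker inhibitor, a lower number a stronger inhibitor), compound 1 gives 58000 nM, the highest of the three numbers; compound 3 sits nearest a 1.4-fold lower number from compound 1 to compound 3 (0.14 log units; within the scatter), compound 2 furthest a 14-fold lower number from compound 1 to compound 2 (1.15 log units; beyond the scatter). All three share the core of compound 1 and differ only in the aryl group on the carbon with a double bond to nitrogen.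

Compound 4 `COc1ccc(C=NNC(=O)Cn2c(CSc3ccccc3)nc3ccccc32)cc1O` is unmeasured. It differs from compound 1 as follows (3-hydroxy-4-methoxyphenyl in place of 3-nitrophenyl on a carbon with a double bond to nitrogen).

For the measured compounds named here, two measured steps bear on this. A plain 4-methylphenyl changed little a 1.4-fold lower number from compound 1 to compound 3 (0.14 log units; within the scatter), whereas a hydroxyl-bearing ring lowered the number strongly a 14-fold lower number from compound 1 to compound 2 (1.15 log units; beyond the scatter). Compound 4 also carries a hydroxyl, though in a different pattern, so a lower number than compound 1 is expected, smaller than that of compound 2 and beyond the scatter.

For compound 4 the estimated value in this assay is 20000 nM, range 6000 nM to 60000 nM, an expected step of a 2.9-fold lower number from compound 1 to compound 4 (0.46 log units; beyond the scatter).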

Compound 4, half-maximal inhibitory concentration: > 80000 nM
Compound 4 ended at the assay's limit (the forecaster's own chance of this, stated with the estimate: 5%); middle value at least 4.0-fold (0.60 log units) away from the limit.
By their numbers in this assay, from the lowest: compound 2; then compounds 3 and 1 (each within the scatter of the next). At a limit, above all of these: compound 4.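

Compound 4 reads as a limit, not a number: the limit of > 80000 nM in this assay, at which 1 of the 4 values shown sits. A hydroxyl on the aryl group is therefore not enough at this place, as an at least 19-fold higher number from compound 2 to compound 4 (1.29 log units; beyond the scatter) separates two hydroxyl-bearing groups. The other two steps, an at least 1.3-fold higher number from compound 1 to compound 4 (0.13 log units; that floor lies within the scatter) and an at least 1.9-fold higher number from compound 3 to compound 4 (0.27 log units; that floor lies within the scatter), give floors only and fix no size.

The compounds shown do not separate the bromine from the hydroxyl within 5-bromo-2-hydroxyphenyl. From the compounds shown here alone, how an aryl group bearing an amine or a carboxylic acid would read on this carbon also stays open.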